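Straightening and lengthening the alkyl chain of compound 3

The source may hold more compounds than are shown below. What is called first, only, known or untested is meant among the compounds shown, and "the series" means these compounds.

Among three compounds that share one core, compound 3 `CCc1ccc(C(=O)NN(C(=O)CCC(C)C)C(C)(C)C)cc1` gives the lowest number in an assay on cells for agonist activity at ecdysone receptor (Bombyx mori), read by a luciferase reporter, with a stated time of 24 h (on this read-out higher numbers stand for an effect only at larger amounts of compound and lower numbers for an effect already at smaller amounts), at 832 nM. Compound 1 `CCOc1ccccc1C(=O)N(NC(=O)c1ccc(CC)cc1)C(C)(C)C` gives 2880 nM in this assay, and compound 2 `CCCCCCC(=O)N(NC(=O)c1ccccc1)C(C)(C)C` gives 7240 nM. For the measured compounds named here, the only change measured in a single place is a 3.5-fold lower number from compound 1 to compound 3 (0.54 log units; beyond the scatter), a modest step that exchanged an aromatic group for a short branched chain. Compound 4 `CCCCCCC(=O)N(NC(=O)c1ccc(CC)cc1)C(C)(C)C` keeps everything of compound 3 except that (butyl in place of isopropyl on a saturated chain carbon, two bonds along the chain from a carbonyl carbon); the chain loses its branch and grows longer. Going by the values given here, no measured step tests that kind of change on its own. Among the compounds with values here, compound 2 carries the same unbranched chain as compound 4 but also differs from compound 3 in a second place, so its value beside that of compound 3 shows only that the two changes together gave a higher number. The step from compound 1 to compound 3 concerns a different exchange and cannot settle the direction. With the lengthening untested by itself, a small to modest rise in the number is expected, a 2.4-fold higher number from compound 3 to compound 4 (0.38 log units; beyond the scatter). For compound 4 the estimate in this assay is 2000 nM, with a likely range from 700 nM to 6000 nM.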

Compound 4, half-maximal effective concentration: 11700 nM
The estimate for compound 4 lay 5.9-fold (0.77 log units) below the measured number; measured number above the stated range.
By their numbers in this assay, from the lowest: compound 3; then compound 1; then compounds 2 and 4 (each within the scatter of the next).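

In this assay, exchanging isopropyl for butyl at this chain carbon gives a 14-fold higher number from compound 3 to compound 4 (1.15 log units; beyond the scatter), so the branched isopentyl chain and the straight hexyl chain are far from interchangeable on this carbonyl carbon, even though the change adds only a little to the chain. The order of the chain and the aromatic group also depends on the chain's shape: isopentyl gave a 3.5-fold lower number from compound 1 to compound 3 (0.54 log units; beyond the scatter), whereas hexyl gives a 4.1-fold higher number from compound 1 to compound 4 (0.61 log units; beyond the scatter), and with hexyl in place, ethyl on an aromatic carbon shows only a 1.6-fold higher number from compound 2 to compound 4 (0.21 log units; within the scatter). No measurement available here accounts for the large jump.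

On these data alone, this single step removes the branch and lengthens the chain at once, so the contribution of each stays open. A straight pentyl chain or a longer branched chain on the carbonyl carbon would help separate the two.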